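The compounds below may be only part of what the source reports. "The series", "measured", "known", "first", "only" and "open" are said of these compounds alone.

Compound 1 `CNC(=O)/C=C/c1ccncc1-c1ccc2ccccc2c1`: 6550 nM
Compound 2 `NNC(=O)COc1ccncc1-c1ccc2ccccc2c1`: "not determined" (no result reported)
Compound 3 `O=C(CCc1ccncc1-c1ccc2ccccc2c1)N1CCOCC1`: > 30000 nM

These three compounds were examined in a functional assay on HCT-116 cells (Homo sapiens) for inhibition, read by MTT assay, with a stated time of 72 h (on this read-out higher numbers stand for weaker inhibition of growth and lower numbers for stronger inhibition of growth), and only compound 1 returned a single number. For compound 2 no result was reported. Compound 3 gives > 30000 nM, which is a limit of the assay and not a number. The set therefore contains (the limit of > 30000 nM in this assay, at which 1 of the 3 values shown sits). For the measured compounds named here, no step between two measured compounds is available, so the size of any effect has not yet been seen.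

The account now turns to compound 4 `O=C(O)CCc1ccncc1-c1ccc2ccccc2c1`, which keeps the core and the saturated chain of compound 3. The change is hydroxy in place of morpholin-4-yl on a carbonyl carbon, so that (morpholin-4-yl)carbonyl becomes carboxy. The expectation rests mainly on compound 3, with its > 30000 nM. In this assay, no shift beyond the scatter is expected, although a modest move towards stronger inhibition of growth cannot be excluded. The estimated change is a number no higher from compound 3 to compound 4 (the limit leaves the size open). The assay may well report only a limit again. As a number, compound 4 is estimated at 30000 nM, within an expected range of 12000 nM to 60000 nM.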

Compound 4, concentration for 50% growth inhibition: > 30000 nM
Compound 4 ended at the assay's limit; the forecaster's own chance of this, stated with the estimate: 65%; the middle value sits exactly at the limit.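

Replacing morpholin-4-yl with hydroxy on the carbonyl carbon leaves the result at the limit of this assay, so the step between compound 3 and compound 4 cannot be read. For the compounds shown here, the new information comes instead from the first readable step: 2-carboxyethyl in place of 2-(methylcarbamoyl)ethenyl on an aromatic carbon gives an at least 4.5-fold higher number from compound 1 to compound 4 (0.66 log units; beyond the scatter), which shows that the group at this position can move the read-out beyond the scatter. Two different ends on the saturated chain, morpholin-4-yl carbonyl and carboxy, now share the same ceiling, so neither can be ranked against the other: (the limit of > 30000 nM in this assay, at which 2 of the 4 values shown sit).

On these data alone, what stays open is whether the stronger inhibition of growth seen with compound 1 belongs to its methylcarbamoyl group or to its ethenyl chain, as the readable step changes both at once. A 2-(methylcarbamoyl)ethyl group or a 2-carboxyethenyl group on the same aromatic carbon would separate the two, and a longer chain ending in an amine would test whether any saturated chain can return a number below the limit.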